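The source may hold more compounds than are shown below. What is called first, only, known or untested is meant among the compounds shown, and "the series" means these compounds.

Compound 1 `CCc1nc(-c2ccc(Cl)cc2Cl)c(CC)nc1NC(CC)CC` gives 0.283 h in an in vitro ADME assay on microsomes (Homo sapiens) for metabolic stability; a higher number here means that the compound lasts longer, a lower number that the compound disappears faster.
Compound 2 `CCOc1nc(-c2ccc(Cl)cc2Cl)c(CC)nc1NC(CC)CC` gives 2 h in this assay.
Compound 3 `CCc1nc(NC(CC)CC)cnc1-c1ccc(Cl)cc1Cl` gives 0.467 h in this assay.

Compound 1 has the lowest of the three numbers. Its nearest neighbour is compound 3, and the gap a 1.7-fold higher number from compound 1 to compound 3 (0.22 log units; within the scatter) lies within the scatter, so nothing separates the two. Compound 2 stands furthest away, with a 7.1-fold higher number from compound 1 to compound 2 (0.85 log units; beyond the scatter) beyond the scatter, and the reverse reading a 4.3-fold lower number from compound 2 to compound 3 (0.63 log units; beyond the scatter) is also beyond it.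

Compound 4 `CCc1nc(-c2ccc(Cl)cc2Cl)c(CC)nc1NC(C1CC1)C1CC1` is the compound to be measured. The change from compound 1 is dicyclopropylmethyl in place of pentan-3-yl on a nitrogen on an aromatic ring. Among the compounds with values here, both measured steps alter a group on an aromatic carbon of the shared core, and neither touches the group on the ring nitrogen, so no measured step bears on this change. With nothing to rest on, the expected step of a 1.1-fold higher number from compound 1 to compound 4 (0.03 log units; within the scatter) is one not beyond the scatter. Compound 4 is therefore estimated at 0.3 h, with a range from 0.12 h to 0.8 h.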

Compound 4, half-life: 0.183 h
Compound 4: the middle estimate sits 1.6-fold (0.21 log units) above what was measured; low and high end bracket the measured number.
By their numbers in this assay, from the lowest: compounds 4, 1 and 3 (each within the scatter of the next, the first and the last beyond it); then compound 2.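

Within the data shown here, compound 4 is the only compound here in which the group on the nitrogen changes, and in this assay the step of a 1.5-fold lower number from compound 1 to compound 4 (0.19 log units; within the scatter) stays within the scatter of repeated measurements. At this place, on a nitrogen on an aromatic ring, dicyclopropylmethyl, with its 2 three-membered rings and 7 heavy atoms against the 5 of pentan-3-yl, therefore cannot be told apart from pentan-3-yl in this read-out. Nothing shown gives a reason for this result.

Going by these compounds, whether the same exchange on the nitrogen would also read this way with ethoxy on the core, as in compound 2, remains open. So does the effect on half-life of a quite different group on that nitrogen, such as a cyclohexyl ring or a chain carrying a hydroxyl.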